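From isopropoxy to (sec-butyl)sulfanyl on the shared core

The source may hold more compounds than are shown below. What is called first, only, known or untested is meant among the compounds shown, and "the series" means these compounds.

Compound 1 `CCC(CC)O[C@@H]1C=C(C(=O)O)C[C@H](NCc2ccc(Cc3ccccc3)cc2)[C@H]1NC(C)=O` gives > 200000 nM as a limit.
Compound 2 `CCC(CC)O[C@@H]1C=C(C(=O)O)C[C@H](NCc2ccc(OC(C)C)cc2)[C@H]1NC(C)=O` gives > 200000 nM as a limit.

In an ADME assay on cells (Fibroblast, Gallus gallus) for cytotoxicity, read by CCK-8 assay, with a stated time of 48 h (on this read-out lower numbers stand for higher toxicity in this test and higher numbers for lower toxicity in this test), compound 2 stands at > 200000 nM as a limit of the assay and not as a number. The whole of the evidence so far is the limit of > 200000 nM in this assay, at which 2 of the 2 values shown sit, and no actual number has been read. Among the measured compounds shown here, the only measured step that bears on the next change is a step that the two limits leave unreadable from compound 1 to compound 2 and it offers no size to carry forward.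

Compound 3 `CCC(CC)O[C@@H]1C=C(C(=O)O)C[C@H](NCc2ccc(SC(C)CC)cc2)[C@H]1NC(C)=O` differs from compound 2 by (sec-butyl)sulfanyl in place of isopropoxy on an aromatic carbon with (sec-butyl)sulfanyl in place of isopropoxy on an aromatic carbon, para to a large group. With compound 2 held at > 200000 nM as a limit, no step beyond the scatter is expected in this assay and no direction can be given. The estimated step is a number no higher from compound 2 to compound 3 (the limit leaves the size open) and a report of only a limit is the likeliest outcome. For compound 3 the expected value is 200000 nM with an estimated range from 90000 nM to 400000 nM.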

Compound 3, half-maximal cytotoxic concentration: > 200000 nM
Compound 3: no number, only a limit (the forecaster's own chance of this, stated with the estimate: 75%); the middle value lies on the limit itself.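

In this assay compound 3 gives > 200000 nM, a limit of the assay and not a number. Among the compounds shown here, compound 1 and compound 2 also stand only at limits, so no step among the three compounds can be read. The compounds shown leave open at what concentration any of them would become cytotoxic, and whether the changes on the aromatic carbon alter that concentration.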